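The source may hold more compounds than are shown below. What is called first, only, known or untested is meant among the compounds shown, and "the series" means these compounds.

Working notes on a functional assay on microsomes for inhibition, with a stated time of 1 h; a lower number here means a stronger inhibitor, a higher number a weaker inhibitor. Compound 1 `Cn1c(NN)nc(-c2ccco2)c(C#N)c1=O` gives 78 ug/mL in this assay, compound 2 `CCOC(=O)c1cnn(-c2nc(-c3ccc(Cl)cc3)c(C#N)c(=O)n2C)c1N` gives 88 ug/mL, and compound 3 `CSc1nc(-c2cccc(O)c2O)c(C#N)c(=O)n1C` gives 41 ug/mL. Compound 2 holds the highest of the three numbers: the gap to compound 1 sits within the scatter, while compound 3 lies beyond the scatter at the lower number. Compound 4 `CCOC(=O)c1cnn(-c2nc(-c3cccc(OC)c3OC)c(C#N)c(=O)n2C)c1N` has not yet been measured in this assay. Against compound 2 the change is 2,3-dimethoxyphenyl in place of 4-chlorophenyl on an aromatic carbon. Among the measured compounds shown here, no step between measured compounds covers such a change, so the direction cannot be read from the series. The expected step is a 1.3-fold lower number from compound 2 to compound 4 (0.10 log units; within the scatter), that is, none beyond the scatter or a modest move toward a lower number. For compound 4 the estimate in this assay is 70 ug/mL, with a range from 30 ug/mL to 160 ug/mL.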

Compound 4, half-maximal inhibitory concentration: 57 ug/mL
Compound 4: the middle estimate sits 1.2-fold (0.09 log units) above what was measured; the range from low to high includes it.
By their numbers in this assay, from the lowest: compounds 3, 4, 1 and 2 (each within the scatter of the next, the first and the last beyond it).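

Among the compounds shown here, this is the first matched pair: in this assay, 2,3-dimethoxyphenyl in place of 4-chlorophenyl on the aromatic carbon ortho to a cyano group gives a 1.5-fold lower number from compound 2 to compound 4 (0.19 log units; within the scatter) and stays inside the usual scatter. At this position, therefore, the read-out does not separate these two substituted phenyl groups, although only the entering group carries hydrogen-bond acceptors. Still open, from the compounds shown here alone, is whether a carboxylic acid or a primary amine on this phenyl ring would give a step beyond the scatter. No measurement bearing on the basis of this result is available.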